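This account rests on a few compounds, and the source may have more. Where it says the series, first, only, none or still open, it means among the compounds named here.

Measured compounds in an assay on isolated protein for agonist activity at Bile acid receptor (Homo sapiens), read by AlphaScreen, with a stated time of 30 min; a higher number here means a larger maximal response, a lower number a smaller maximal response:
compound 1 `Cc1ccccc1-n1nc(C)c2c1NC(=O)[C@H](C)S[C@@H]2c1ccc(-c2ccsc2)cc1` gives 68%
compound 2 `Cc1ccccc1-n1nc(C)c2c1NC(=O)[C@H](C)S[C@@H]2c1ccc(-c2ccco2)cc1` gives 32%
compound 3 `Cc1ccccc1-n1nc(C)c2c1NC(=O)[C@H](C)S[C@@H]2c1ccc(-c2ccccc2)cc1` gives 24%

Compound 3 stands lowest of the three; its nearest neighbour is compound 2, and the step of a number 8 percentage points lower from compound 2 to compound 3 (within the scatter) lies within the scatter, while the step of a number 44 percentage points lower from compound 1 to compound 3 (beyond the scatter) is large. Compound 4 `COc1ccccc1Oc1ccc([C@H]2S[C@@H](C)C(=O)Nc3c2c(C)nn3-c2ccccc2C)cc1` differs from compound 3 by 2-methoxyphenoxy in place of phenyl on an aromatic carbon. For the measured compounds named here, no measured step exchanges phenyl for a phenoxy group, so none bears directly on this change. The steps of a number 36 percentage points lower from compound 1 to compound 2 (beyond the scatter) and a number 44 percentage points lower from compound 1 to compound 3 (beyond the scatter) show that exchanging the group on this aromatic carbon can move the maximal response by large amounts, whereas a number 8 percentage points lower from compound 2 to compound 3 (within the scatter) shows two such groups can also agree. From the bottom of the series, the expected step of a number 6 percentage points higher from compound 3 to compound 4 (within the scatter) is small and uncertain, with more room upward than downward. Compound 4 is estimated at 30%, range 10% to 60%.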

Compound 4, largest response reached (reported as efficacy), in percent of the reference or control that the assay uses: 240%
Compound 4: middle estimate off by 210 percentage points, on the low side; measured number above the stated range.
By their numbers in this assay, from the lowest: compounds 3 and 2 (each within the scatter of the next); then compound 1; then compound 4.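

In this assay, this aromatic carbon, para to a large group, accepts a larger group with an oxygen link, and the response climbs far beyond anything the earlier ring exchanges reached: 2-methoxyphenoxy in place of phenyl gives a number 216 percentage points higher from compound 3 to compound 4 (beyond the scatter) in this series. Against furan-2-yl the same group gives a number 208 percentage points higher from compound 2 to compound 4 (beyond the scatter) and against thiophen-3-yl it gives a number 172 percentage points higher from compound 1 to compound 4 (beyond the scatter) so even the highest earlier compound is clearly passed.

As far as these compounds go, whether the rise needs the methoxy or only the oxygen link stays open, as a plain phenoxy or a benzyloxy group would separate the two. Nothing shown accounts for the size of the rise.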